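Swapping the Aryl Group While Cytotoxicity Stays Unseen

This account rests on a few compounds, and the source may have more. Where it says the series, first, only, none or still open, it means among the compounds named here.

Three compounds sharing one core have been examined in an ADME assay on MT2 cells (Homo sapiens) for cytotoxicity, read by XTT assay, with a stated time of 4 days; on this read-out higher numbers stand for lower toxicity in this test and lower numbers for higher toxicity in this test. Compound 1 `Cc1nc(C(NC(=O)C(=O)Nc2ccc(C(F)(F)F)cc2)C2CCCCN2)sc1CO` returns only an assay limit, > 75500 nM. Compound 2 `Cc1ccc(NC(=O)C(=O)NC(c2nc(C)c(CCO)s2)C2CCCCN2)c(F)c1` likewise stops at a limit, > 78800 nM. Compound 3 `Cc1ccc(NC(=O)C(=O)NC(c2nc(C)c(CO)s2)C2CCCCN2)c(F)c1` also gives a limit, > 109000 nM. Since all three readings are limits, neither a step that the two limits leave unreadable from compound 1 to compound 3 nor a step that the two limits leave unreadable from compound 2 to compound 3 has a readable size.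

Compound 4 `Cc1nc(C(NC(=O)C(=O)Nc2ccc(Cl)cc2)C2CCCCN2)sc1CCO` is not yet measured; it differs from compound 2 by 4-chlorophenyl in place of 2-fluoro-4-methylphenyl on an amide-type nitrogen. The change from compound 1 to compound 3 touches the same amide-type nitrogen, yet its size is unreadable, so no step beyond the scatter can be foreseen. Compound 4 is expected to show a step that the limit leaves unreadable from compound 2 to compound 4. Compound 4 is estimated at 100000 nM, within 50000 nM to 200000 nM.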

Compound 4, half-maximal cytotoxic concentration: > 62000 nM
Compound 4: no number, only a limit; the forecaster's own chance of this, stated with the estimate: 85%; the middle value lies beyond the limit too.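

For the compounds shown here, compound 4, like compound 2, gives only a limit in this assay, so no step between compound 2 and compound 4 can be read. What the compounds shown leave open is how cytotoxic any of them actually is, since no exact value exists.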